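A few compounds are considered here, and "the series" means these few. Any claim that something is new, unique, unknown or untested is made for them only; others in the source may bear on it.

The measured compounds:

Compound 1, `Cc1cc(-c2cccc(C#N)c2)cn2c(CSCCc3ccccc3)cnc12`: in an ADME assay on HEL cells (Homo sapiens) for cytotoxicity, with a stated time of 3 days (on this read-out lower numbers stand for higher toxicity in this test and higher numbers for lower toxicity in this test), compound 1 gives a limit of the assay, > 100 ug/mL.
Compound 2, `Cc1cc(-c2ccc(O)cc2)cn2c(CSCCc3ccccc3)cnc12`: in this assay compound 2 gives a limit of the assay, >= 100 ug/mL.
Compound 3, `Cc1cc(I)c2ncc(CSCCc3ccccc3)n2c1`: in this assay compound 3 gives a limit of the assay, >= 4 ug/mL.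

Compound 2 therefore stands at the limit of >= 100 ug/mL in this assay, at which 1 of the 3 values shown sits, not at a number. The unmeasured compound 4, `Cc1cc(-c2cccc([N+](=O)[O-])c2)cn2c(CSCCc3ccccc3)cnc12`, differs from compound 2 in one place: 3-nitrophenyl in place of 4-hydroxyphenyl on an aromatic carbon. Among the compounds with values here, the only measured step that bears on this position is a step that the two limits leave unreadable from compound 1 to compound 2, and since both ends are limits, its size cannot be read. No readable step exists, so no direction is expected beyond the scatter. Compound 4 is expected near 100 ug/mL, within 40 ug/mL to 200 ug/mL, and the expected step is a number no higher from compound 2 to compound 4 (the limit leaves the size open).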

Compound 4, minimum cytotoxic concentration: >= 100 ug/mL
Compound 4 gave a limit, no number; the forecaster's own chance of this, stated with the estimate: 80%; the middle value lies on the limit itself.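

Within the data shown here, compound 1, compound 2 and compound 4 each give only a limit, not a number, so no step among them can be read. From the compounds shown here alone, whether their 3-cyanophenyl, 4-hydroxyphenyl and 3-nitrophenyl groups differ at all in this assay stays open.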